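A few compounds are considered here, and "the series" means these few. Any claim that something is new, unique, unknown or untested is made for them only; others in the source may bear on it.

In a functional assay on U-251 cells (Homo sapiens) (a lower number here means a stronger inhibitor of growth, a higher number a weaker inhibitor of growth), compound 1 (`COc1ccc(-c2cc(O)c3cccnc3n2)cc1`) gives 53700 nM and compound 2 (`COc1ccc(-c2cc(O)c3c(C)cc(C)nc3n2)cc1`) gives 91200 nM, two values that lie within the usual scatter of each other. Compound 3 (`COc1ccccc1-c1cc(O)c2ccc(C)nc2n1`) gives > 100000 nM, which is a limit of the assay and not a number. Going by the values given here, its true position is therefore unknown, and no measured pair in the set isolates a single structural change.

Compound 4 (`COc1ccccc1-c1cc(O)c2cccnc2n1`) departs from compound 3 by one small edit, hydrogen in place of methyl on an aromatic carbon. The closest guide is indirect: compound 1 at 53700 nM and compound 2 at 91200 nM show that the two cores, with and without methyl groups, sit close together in this assay. A modest shift toward stronger inhibition of growth is therefore expected, possibly none beyond the scatter, and compound 4 may also stay at the limit. The estimated change is an at least 1.3-fold lower number from compound 3 to compound 4 (0.12 log units; that floor lies within the scatter). Compound 4 is expected at about 75000 nM, with an estimated range from 35000 nM to 100000 nM.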

Compound 4, concentration for 50% growth inhibition: 67600 nM
Compound 4: the middle estimate sits 1.1-fold (0.05 log units) above what was measured; the range from low to high includes it.
By their numbers in this assay, from the lowest: compounds 1, 4 and 2 (each within the scatter of the next). At a limit, above all of these: compound 3.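

In this assay, going by these compounds alone, hydrogen in place of methyl on an aromatic carbon next to the ring nitrogen gives the first step in the set that isolates a single structural change: an at least 1.4-fold lower number from compound 3 to compound 4 (0.17 log units; that floor lies within the scatter). Going by these compounds, compound 3 stands at a limit of the assay, so this step is only a floor and its true size remains unknown: the limit of > 100000 nM in this assay, at which 1 of the 4 values shown sits. Without the methyl, compound 4 gives a measured number of 67600 nM. The floor of the step lies within the scatter and does not establish that the methyl weakens growth inhibition.

The compounds shown leave open how this position responds to any group other than methyl or hydrogen, such as an amine, a chlorine atom or a longer chain. On these data alone, it also remains open whether the same edit would give a comparable step on the core of compound 1.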